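Pyrrolidinyl amide replaces dimethylamide in a fatty acid receptor series

The source may hold more compounds than are shown below. What is called first, only, known or untested is meant among the compounds shown, and "the series" means these compounds.

compound 1, `O=C(O)[C@H]1C[C@@H]1c1ccc(NCc2cccc(Oc3ccccc3)c2)cc1`: 88%; 72% (2 entries)
compound 2, `NC(=O)CCc1ccc(NCc2cccc(Oc3ccccc3)c2)cc1`: 68%
compound 3, `CN(C)C(=O)CCc1ccc(NCc2cccc(Oc3ccccc3)c2)cc1`: 50%

The three measured compounds share one core and differ only in the group at the end of the side chain. In a functional assay on CHO cells for agonist activity at Free fatty acid receptor 1 (Homo sapiens), read by a luciferase reporter (a higher number here means a larger maximal response, a lower number a smaller maximal response), compound 3 stands lowest of the two compounds with a single number; the nearest is compound 2, and the drop a number 18 percentage points lower from compound 2 to compound 3 (beyond the scatter) lies beyond the scatter. Compound 1 was measured twice, and the several entries of compound 1 in this assay, 88%; 72% (2 entries) shows how far two runs of the same compound can lie apart.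

Compound 4, `O=C(CCc1ccc(NCc2cccc(Oc3ccccc3)c2)cc1)N1CCCC1`, has not yet been measured. It differs from compound 3 in one place: pyrrolidin-1-yl in place of dimethylamino on a carbonyl carbon

Going by the values given here, no measured step bears directly on this change; the only step, a number 18 percentage points lower from compound 2 to compound 3 (beyond the scatter), concerns the loss of the amino group and is modest. Exchanging one group without donors or acceptors for another of the same kind gives no measured reason to expect a shift, so the step from compound 3 to compound 4 in this assay is expected to stay within the scatter, a number 2 percentage points lower from compound 3 to compound 4 (within the scatter). For compound 4 in this assay the estimate is 48%, with a range from 30% to 66%.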

Compound 4, largest response reached (reported as percent of maximum), in percent of the reference or control that the assay uses: 46%
Estimate against measurement, compound 4: 2 percentage points above; the range from low to high includes it.
By their numbers in this assay, from the lowest: compounds 4 and 3 (each within the scatter of the next); then compound 2.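

In this assay, going by these compounds alone, this is the first change on the carbonyl carbon that brings in a ring: pyrrolidin-1-yl, with one five-membered non-aromatic ring and 5 heavy atoms, in place of dimethylamino, with no ring and 3 heavy atoms, gives a number 4 percentage points lower from compound 3 to compound 4 (within the scatter). At this position, then, the ring and the two extra heavy atoms leave the maximal response where it was, and the two groups cannot be told apart by this read-out. The new compound also repeats the earlier picture at a second group, because replacing amino with pyrrolidin-1-yl gives a number 22 percentage points lower from compound 2 to compound 4 (beyond the scatter), much as dimethylamino gave a number 18 percentage points lower from compound 2 to compound 3 (beyond the scatter), though a small gap must be read against how far repeat runs can differ: the several entries of compound 1 in this assay, 88%; 72% (2 entries)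

The compounds shown leave open what methylamino, between amino and dimethylamino in its substitution, would give on the same carbonyl carbon, and whether piperidin-1-yl or morpholin-4-yl would read like pyrrolidin-1-yl. They also leave open whether a carboxylic acid at the end of this saturated chain would restore a larger response.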